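Predicting Compound 4 from Three Ring-Substituent Swaps

The compounds below may be only part of what the source reports. "The series", "measured", "known", "first", "only" and "open" are said of these compounds alone.

Three compounds have been tested in an assay on HEK293 cells for inhibition of Voltage-dependent T-type calcium channel subunit alpha-1G (Homo sapiens), read by patch clamp; on this read-out lower numbers stand for stronger inhibition and higher numbers for weaker inhibition:
Compound 1 `CCCc1nc(-c2ccccc2)c(CNCCCN2CCN(c3ccccc3Cl)CC2)o1` gives 2800 nM.
Compound 2 `CCCc1nc(-c2ccccc2)c(CNCCCN2CCN(c3ccc(C(F)(F)F)cc3)CC2)o1` gives 7250 nM.
Compound 3 `CCCc1nc(-c2ccccc2)c(CNCCCN2CCN(c3cccc(C)c3C)CC2)o1` gives 1780 nM.

Compound 3 has the lowest number of the three, but its gap to compound 1 is within the scatter, as the step from compound 1 to compound 3 shows: a 1.6-fold lower number from compound 1 to compound 3 (0.20 log units; within the scatter). Only compound 2 sits clearly apart, with a 4.1-fold lower number from compound 2 to compound 3 (0.61 log units; beyond the scatter), and a 2.6-fold higher number from compound 1 to compound 2 (0.41 log units; beyond the scatter) points the same way.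

Compound 4 `CCCc1nc(-c2ccccc2)c(CNCCCN2CCN(c3ccccc3F)CC2)o1` differs from compound 3 in a single place: 2-fluorophenyl in place of 2,3-dimethylphenyl on an amine nitrogen in a ring. For the measured compounds named here, the step that bears most on this change is the one between compound 1 and compound 3. Compound 1 carries a 2-chlorophenyl group, the nearest counterpart to the incoming 2-fluorophenyl group, and that step was within the scatter. A 2-fluorophenyl group is therefore expected to land near compound 1 and compound 3, with no step beyond the scatter. Compound 4 is estimated at 2500 nM, between 1000 nM and 6000 nM, which would mean an expected step of a 1.4-fold higher number from compound 3 to compound 4 (0.15 log units; within the scatter).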

Compound 4, half-maximal inhibitory concentration: 16100 nM
Compound 4: the middle estimate sits 6.4-fold (0.81 log units) below what was measured; the measured number lies above the stated range.
By their numbers in this assay, from the lowest: compounds 3 and 1 (each within the scatter of the next); then compound 2; then compound 4.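

In this assay, fluoro in place of chloro on the same aromatic carbon is not a minor exchange, giving a 5.8-fold higher number from compound 1 to compound 4 (0.76 log units; beyond the scatter) even though compound 1 and compound 4 differ in this one place alone. The 2-fluorophenyl group now gives the highest number of the set, with a 9.0-fold higher number from compound 3 to compound 4 (0.96 log units; beyond the scatter) and with a 2.2-fold higher number from compound 2 to compound 4 (0.35 log units; beyond the scatter), so the group on this ring nitrogen covers a wider range than the first three compounds revealed. Nothing available here explains this result.

On these data alone, whether a plain phenyl or a 2-methoxyphenyl group on the same ring nitrogen would sit nearer compound 1 or compound 4 remains open. As far as these compounds go, it is also open whether the fluoro and chloro groups would differ as much with a longer chain in the linker of the shared core.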